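Series notes: from compound 1 toward compound 4

This account rests on a few compounds, and the source may have more. Where it says the series, first, only, none or still open, it means among the compounds named here.

Measured so far:
compound 1, `N/C(=N\C(=O)NCc1ccccc1)NC1CCc2nc(N)sc2C1`, gives 513 nM
compound 2, `Cc1nc(N)sc1CCCN/C(N)=N/C(=O)NC(C)c1ccc(OC(F)(F)F)cc1`, gives 126 nM
compound 3, `Cc1nc(N)sc1CCCN/C(N)=N/C(=O)NCC(C)CC1CCCCC1`, gives 70.8 nM

All three values come from an assay on membranes from Sf9 cells for displacement of a labelled ligand from histamine H2 receptor (Homo sapiens), read by scintillation counting, with a stated time of 60 min; on this read-out higher numbers stand for weaker inhibition and lower numbers for stronger inhibition. Compound 1 stands at the highest of the three numbers and is the weakest inhibitor of the set; compound 2 lies nearest to it and compound 3 furthest, both differences beyond the scatter. Compounds 2 and 3 carry a core unlike that of compound 1, so neither pair is a single-point step and their values are read only side by side.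

Compound 4, `CCCCCCNC(=O)/N=C(\N)NC1CCc2nc(N)sc2C1`, differs from compound 1 in one place: pentyl in place of phenyl on a saturated chain carbon bound to an amide-type nitrogen. For the measured compounds named here, no measured pair isolates this change. Compound 3, where a saturated chain rather than an aromatic ring sits on the amide-type nitrogen, gives 70.8 nM, but with a different core that comparison cannot be carried over. Compound 4 is therefore expected to give 380 nM in this assay, with a range of 150 nM to 1000 nM. The estimated change, a 1.4-fold lower number from compound 1 to compound 4 (0.13 log units; within the scatter), is small, if anything toward a lower number, and may well lie within the scatter.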

Compound 4, inhibition constant: 1120 nM
Beside the measured number, compound 4's estimate is 2.9-fold (0.47 log units) below it; the measured number lies above the stated range.
By their numbers in this assay, from the lowest: compounds 3 and 2 (each within the scatter of the next); then compound 1; then compound 4.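

For the compounds shown here, this is the first step that changes one place alone: in this assay, putting pentyl in place of phenyl on a saturated chain carbon bound to an amide-type nitrogen gives a 2.2-fold higher number from compound 1 to compound 4 (0.34 log units; beyond the scatter). On the core of compound 1, then, the aromatic ring at this position can be exchanged for an open saturated chain with only a modest loss of inhibition, so the ring is not required for a measurable affinity, yet the chain does not match it; read one bond further out, the same change is benzyl to hexyl, or benzylamino to hexylamino. The data shown offer no independent measurement that would explain this step.

Still open, on these data alone, is whether the modest step reflects the loss of the ring or the particular chain, as a single pair cannot separate the two, and a longer chain or a chain ending in an amine would test how far this position tolerates change on the shared core. Also open, as far as these compounds go, is whether the same exchange gives a step of like direction and size on the core carried by compound 2 and compound 3.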